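Chloro in place of methoxy: estimate for compound 4

This account rests on a few compounds, and the source may have more. Where it says the series, first, only, none or still open, it means among the compounds named here.

Compound 3 `COc1ccc(-n2nc(C(=O)Nc3ccc(Oc4ccnc5cc(OCCCN6CCCCC6)c(OC)cc45)c(F)c3)c(C)cc2=O)cc1` stands second highest of the three numbers in a functional assay on MKN-45 cells (Homo sapiens) for inhibition, read by MTT assay, with a stated time of 72 h (on this read-out lower numbers stand for stronger inhibition and higher numbers for weaker inhibition), where compound 3 gives 330 nM; compound 1 `COc1cc2c(Oc3ccc(NC(=O)c4nn(-c5ccccc5C)c(=O)cc4C)cc3F)ccnc2cc1OCCCN1CCCCC1` gives 1310 nM and compound 2 `COc1cc2c(Oc3ccc(NC(=O)c4nn(-c5ccccc5C(F)(F)F)c(=O)cc4C)cc3F)ccnc2cc1OCCCN1CCCCC1` gives 90 nM. All measured steps alter the group on the aromatic nitrogen: a 15-fold lower number from compound 1 to compound 2 (1.16 log units; beyond the scatter), a 4.0-fold lower number from compound 1 to compound 3 (0.60 log units; beyond the scatter) and a 3.7-fold higher number from compound 2 to compound 3 (0.56 log units; beyond the scatter). Compound 4 `COc1cc2c(Oc3ccc(NC(=O)c4nn(-c5ccc(Cl)cc5)c(=O)cc4C)cc3F)ccnc2cc1OCCCN1CCCCC1` differs from compound 3 by chloro in place of methoxy on an aromatic carbon. Among the measured compounds shown here, no measured step exchanges one group for another on the 4-methoxyphenyl of compound 3, so the pairs above give no direct guide, and nothing in them points to a step beyond the scatter for this exchange. Compound 4 is thus expected to show a 1.1-fold lower number from compound 3 to compound 4 (0.04 log units; within the scatter). In this assay compound 4 is estimated at 300 nM, within 100 nM to 900 nM.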

Compound 4, half-maximal inhibitory concentration: 230 nM
Estimate against measurement, compound 4: 1.3-fold (0.12 log units) above; low and high end bracket the measured number.
By their numbers in this assay, from the lowest: compound 2; then compounds 4 and 3 (each within the scatter of the next); then compound 1.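

In this assay, chloro in place of methoxy para to a large group gives a step within the scatter (a 1.4-fold lower number from compound 3 to compound 4 (0.16 log units; within the scatter)), so at this position the two groups are not told apart. Against the other aryl groups on the aromatic nitrogen, 4-chlorophenyl trails 2-(trifluoromethyl)phenyl (a 2.6-fold higher number from compound 2 to compound 4 (0.41 log units; beyond the scatter)) and outdoes 2-methylphenyl (a 5.7-fold lower number from compound 1 to compound 4 (0.76 log units; beyond the scatter)), the same order as for 4-methoxyphenyl. No measurement on hand bears on why these steps take this size. Open, on these data alone, is whether an amine or a carboxylic acid at this position keeps the number near those of compound 3 and compound 4.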